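The compounds below may be only part of what the source reports. "The series", "measured", "known", "first", "only" and "open" are said of these compounds alone.

Within the data shown here, compound 2 `CCCC(C)Cn1c(N2CCN(C)CC2)nc2ccccc21` gives 500 nM in a functional assay on ileum for inhibition of histamine H1 receptor (Cavia porcellus) (on this read-out lower numbers stand for stronger inhibition and higher numbers for weaker inhibition), the higher of the two numbers recorded so far in this assay; its only neighbour is compound 1 `CCCCOCCn1c(N2CCN(C)CC2)nc2ccccc21`, which gives 38 nM, and the step of a 13-fold higher number from compound 1 to compound 2 (1.12 log units; beyond the scatter) was large. The next compound, compound 3 `CC(C)CCn1c(N2CCN(C)CC2)nc2ccccc21`, differs from compound 2 by isobutyl in place of 1-methylbutyl on a saturated chain carbon bound to an aromatic nitrogen. Among the measured compounds shown here, only one measured step exists, and it traded an oxygen-containing butoxymethyl for a pure hydrocarbon 1-methylbutyl; the move to isobutyl keeps a hydrocarbon chain while shortening it and shifting the branch, so that step bears on it only loosely. Without a comparable measured change, no direction beyond the scatter can be argued with confidence. Compound 3 is therefore expected to give about 300 nM in this assay, within a range from 80 nM to 1500 nM, a step of a 1.7-fold lower number from compound 2 to compound 3 (0.22 log units; within the scatter) that is estimated to stay close to compound 2.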

Compound 3, half-maximal inhibitory concentration: 1400 nM
The estimate for compound 3 lay 4.7-fold (0.67 log units) below the measured number; measured number inside the range.
By their numbers in this assay, from the lowest: compound 1; then compound 2; then compound 3.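

In this assay, the place on a saturated chain carbon bound to an aromatic nitrogen proves sensitive even to a change from one hydrocarbon group to another: isobutyl in place of 1-methylbutyl gives a 2.8-fold higher number from compound 2 to compound 3 (0.45 log units; beyond the scatter) and so moves the number beyond the scatter. Set against the butoxy chain, isopropyl on a saturated chain carbon, two bonds along the chain from an aromatic nitrogen, gives a far larger change, a 37-fold higher number from compound 1 to compound 3 (1.57 log units; beyond the scatter), which places compound 1 lowest and compound 3 highest of the three. No evidence is available that would account for either step.

As far as these compounds go, it remains open whether the lower number of compound 1 goes with the oxygen in its chain or with the length of that chain. A straight hexyl chain or a shorter methoxy ether at this place would help separate the two.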